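Shifting a Fluorine from Compound 3 to Compound 4

The compounds below may be only part of what the source reports. "The series", "measured", "known", "first", "only" and "open" are said of these compounds alone.

Three measured compounds share one core and differ only in the group on one aromatic carbon of the five-membered ring. Compound 1 `CCc1nc(-c2ccc(COc3cccc(C(=O)NO)c3)cc2)no1` carries an ethyl there; in an assay on isolated protein for inhibition of sphingomyelin phosphodiesterase (Homo sapiens), read by fluorescence, with a stated time of 30 min (a lower number here means a stronger inhibitor, a higher number a weaker inhibitor), compound 1 gives 34700 nM. Compound 2 `O=C(NO)c1cccc(OCc2ccc(-c3noc(-c4ccccc4)n3)cc2)c1` carries a phenyl instead. In this assay compound 2 reaches only the limit of > 100000 nM, which is not a number. Compound 3 `O=C(NO)c1cccc(OCc2ccc(-c3noc(-c4ccccc4F)n3)cc2)c1` carries a 2-fluorophenyl. In this assay compound 3 likewise stands at the limit of > 100000 nM. The steps of an at least 2.8-fold higher number from compound 1 to compound 2 (0.45 log units; beyond the scatter) and an at least 2.8-fold higher number from compound 1 to compound 3 (0.45 log units; beyond the scatter) both show that swapping ethyl for an aryl group weakens inhibition, while a step that the two limits leave unreadable from compound 2 to compound 3 cannot be read because of the limit of > 100000 nM in this assay, at which 2 of the 3 values shown sit. Compound 4 `O=C(NO)c1cccc(OCc2ccc(-c3noc(-c4cccc(F)c4)n3)cc2)c1` differs from compound 3 by 3-fluorophenyl in place of 2-fluorophenyl on an aromatic carbon. Within the data shown here, no measured step tells what moving the fluorine does, and both aryl compounds already sit at the limit, so no change beyond the scatter is expected in this assay: the step that the limit leaves unreadable from compound 3 to compound 4 is expected to be small. Compound 4 is estimated at 150000 nM, within 40000 nM to 600000 nM, most likely reported again as a limit.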

Compound 4, half-maximal inhibitory concentration: > 100000 nM
Compound 4 was reported as a limit; the forecaster's own chance of this, stated with the estimate: 75%; the middle value does not contradict the limit.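

Moving the fluorine to give a 3-fluorophenyl does not recover the inhibition seen with ethyl in this assay, and the result is an at least 2.8-fold higher number from compound 1 to compound 4 (0.45 log units; beyond the scatter). Compound 4 gives > 100000 nM, which is a limit of the assay and not a number. All three aryl groups shown therefore fall on the weak side of ethyl, but the steps among these aryl compounds cannot be read because their values rest on the same limit: the limit of > 100000 nM in this assay, at which 3 of the 4 values shown sit.

As far as these compounds go, whether the fluorine, or its place on the phenyl ring, changes inhibition at all stays open, as does whether any aryl group at this position can give a measurable value. Also open, from the compounds shown here alone, is how a methyl, a propyl chain or an amine on the same aromatic carbon would compare with ethyl.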